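The source may hold more compounds than are shown below. What is called first, only, known or untested is meant among the compounds shown, and "the series" means these compounds.

Measured so far in an ADME assay on HCT-116 cells (Homo sapiens) for cytotoxicity, read by MTT assay, with a stated time of 72 h; a higher number here means a weaker inhibitor, a lower number a stronger inhibitor:
compound 1, `COc1ccc(OC)c(NC(=O)c2cccc(/C=C3\CC(=O)N(c4ccccc4)C3=O)c2)c1`: compound 1 gives > 100000 nM, which is a limit of the assay, not a number
compound 2, `CSc1cccc(NC(=O)c2cccc(/C=C3\CC(=O)N(c4ccccc4)C3=O)c2)c1`: compound 2 gives 65200 nM

Compound 2 therefore holds the only number shown in this assay; the other value is a limit. Within the data shown here, the one measured step, from compound 1 to compound 2, reads an at least 1.5-fold lower number from compound 1 to compound 2 (0.18 log units; that floor lies within the scatter); its true size stays open because it starts from the limit of > 100000 nM in this assay, at which 1 of the 2 values shown sits.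

Compound 3, `O=C(Nc1ccc(Cl)cc1)c1cccc(/C=C2\CC(=O)N(c3ccccc3)C2=O)c1`, differs from compound 2 by 4-chlorophenyl in place of 3-(methylsulfanyl)phenyl on an amide-type nitrogen. Among the measured compounds shown here, no measured step exchanges these two groups, and the only step on record in this assay is both small and bounded by a limit, so it gives no direction for the change. The expected step is a 1.1-fold lower number from compound 2 to compound 3 (0.04 log units; within the scatter), nothing beyond the scatter. Compound 3 is estimated at 60000 nM, with a range from 25000 nM to 150000 nM, and a real chance that only a limit is reported.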

Compound 3, half-maximal inhibitory concentration: > 100000 nM
Compound 3 was reported as a limit (the forecaster's own chance of this, stated with the estimate: 35%); middle value at least 1.6-fold (0.22 log units) from the limit.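

In this assay, 4-chlorophenyl in place of 3-(methylsulfanyl)phenyl on the amide-type nitrogen gives an at least 1.5-fold higher number from compound 2 to compound 3 (0.18 log units; that floor lies within the scatter). Compound 3 gives > 100000 nM, which is a limit of the assay and not a number. Compound 2 therefore still holds the only number at this position, and neither the true size of this step nor the step from compound 1 to compound 3 can be read, because: the limit of > 100000 nM in this assay, at which 2 of the 3 values shown sit.

As far as these compounds go, it remains open whether the sulfur-bearing group itself matters, or whether a group such as 4-(methylsulfanyl)phenyl or 3-chlorophenyl on the same nitrogen would give a number in this assay. Also open, from the compounds shown here alone, is how a phenyl ring carrying a carboxylic acid or a dimethylamino group would read at this position.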